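Cyclohexyl to 4-methylphenyl on the ring amide nitrogen

A few compounds are considered here, and "the series" means these few. Any claim that something is new, unique, unknown or untested is made for them only; others in the source may bear on it.

Measured compounds:
- compound 1, `O=C1COc2ccc(-c3cnc4ccccc4c3)cc2N1C1CCCCC1`; in a functional assay on A-375 cells (Homo sapiens) for antiproliferative activity, read by MTT assay, with a stated time of 72 h (a lower number here means a stronger inhibitor, a higher number a weaker inhibitor), compound 1 gives only a limit of the assay, > 40000 nM.
- compound 2, `Cc1ccc(N2C(=O)COc3ccc(-c4cnc5ccccc5c4)cc32)cc1`; in this assay compound 2 gives only a limit of the assay, > 40000 nM.
- compound 3, `O=C1COc2ccc(-c3cccc(NS(=O)(=O)c4ccc(F)cc4)c3)cc2N1C1CCCCC1`; in this assay compound 3 gives 23800 nM.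

Compound 3 is the only one of the three with a number rather than a limit. Compound 1 and compound 2 are related by a single change, (4-methylphenyl in place of cyclohexyl on an amide-type nitrogen in a ring), and the step that the two limits leave unreadable from compound 1 to compound 2 cannot be sized, because the limit of > 40000 nM in this assay, at which 2 of the 3 values shown sit, holds both of them. Compound 3 differs from compound 1 in its core; the difference between the two cores is not broken down here.

Compound 4, `Cc1ccc(N2C(=O)COc3ccc(-c4cccc(NS(=O)(=O)c5ccc(F)cc5)c4)cc32)cc1`, has not been measured. It stands to compound 3 as compound 2 stands to compound 1: the change is 4-methylphenyl in place of cyclohexyl on an amide-type nitrogen in a ring, the same change as before, made on the core of compound 3 instead. For the measured compounds named here, the one prior instance of this change, a step that the two limits leave unreadable from compound 1 to compound 2, gives no readable size, so the expectation for compound 4 rests mainly on compound 3 at 23800 nM. Compound 4 is therefore expected to sit close to compound 3, with a step of a 1.3-fold higher number from compound 3 to compound 4 (0.13 log units; within the scatter) of modest size and a real chance of falling back to a limit. The estimate for compound 4 in this assay is 32000 nM, within 9000 nM to 100000 nM.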

Compound 4, half-maximal inhibitory concentration: 36200 nM
Estimate against measurement, compound 4: 1.1-fold (0.05 log units) below; the measured number falls inside the stated range.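

In this assay, 4-methylphenyl in place of cyclohexyl on an amide-type nitrogen in a ring gives a 1.5-fold higher number from compound 3 to compound 4 (0.18 log units; within the scatter), so on this core the two groups cannot be told apart. The other instance of the change, on the core of compound 1, cannot be read, because compound 1 and compound 2 both give only a limit of the assay: the limit of > 40000 nM in this assay, at which 2 of the 4 values shown sit. The series therefore holds one readable step for this change, which shows no difference beyond the scatter on a single core but does not show whether the change behaves alike on both cores.

Still open, from the compounds shown here alone, is whether any other group on this amide-type nitrogen, such as a short chain like ethyl or a longer chain ending in an amine, would move the number beyond the scatter in this assay. Also open, going by these compounds, is whether replacing the fluorine of compound 3 with a carboxylic acid or an amine would give a step large enough to show how this nitrogen substituent matters when the number is no longer close to the limit of the assay.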